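Phenyl in Place of 3-Methylbenzyl on the Ring Nitrogen

The source may report more compounds than this note shows. Statements on the series, on what has been measured and on what is new or still open speak of the compounds shown alone.

Measured compounds:
compound 1 `CCCn1c(=O)[nH]c2nc(-c3ccc(S(=O)(=O)N4CCN(Cc5cccc(C)c5)CC4)cc3)[nH]c2c1=O`: 0.397 nM
compound 2 `CCCn1c(=O)[nH]c2nc(-c3ccc(S(=O)(=O)N4CCN(c5ccccc5C)CC4)cc3)[nH]c2c1=O`: 0.432 nM

In an assay on CHO cells for displacement of a labelled ligand from adenosine receptor A2b (Homo sapiens), read by scintillation counting, with a stated time of 75 min, in the presence of a further agent that is not named here (on this read-out higher numbers stand for weaker inhibition and lower numbers for stronger inhibition), compound 1 gives 0.397 nM, while compound 2 gives 0.432 nM; the two values lie within the scatter of each other, so compound 1 cannot be set apart from compound 2 on these numbers. Compound 3 `CCCn1c(=O)[nH]c2nc(-c3ccc(S(=O)(=O)N4CCN(c5ccccc5)CC4)cc3)[nH]c2c1=O` differs from compound 1 by phenyl in place of 3-methylbenzyl on an amine nitrogen in a ring. Among the compounds with values here, the one measured step that bears on this, a 1.1-fold higher number from compound 1 to compound 2 (0.04 log units; within the scatter), also exchanged 3-methylbenzyl for an aromatic group, 2-methylphenyl, on the same ring nitrogen and stayed within the scatter. Compound 3 is therefore expected to show no step beyond the scatter, a 1.1-fold higher number from compound 1 to compound 3 (0.05 log units; within the scatter), with an estimated value of 0.45 nM (range 0.2 nM to 1 nM).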

Compound 3, inhibition constant: 0.643 nM
The estimate for compound 3 lay 1.4-fold (0.15 log units) below the measured number; the range from low to high includes it.
By their numbers in this assay, from the lowest: compounds 1, 2 and 3 (each within the scatter of the next).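

In this assay, phenyl on the ring nitrogen stays within the scatter of 3-methylbenzyl, a 1.6-fold higher number from compound 1 to compound 3 (0.21 log units; within the scatter), so this position tolerates an aromatic ring carried directly on the nitrogen even without a methyl on it. Hydrogen in place of methyl on the aromatic carbon, a 1.5-fold higher number from compound 2 to compound 3 (0.17 log units; within the scatter), also stays within the scatter, so that methyl is not needed to hold the value. No evidence bearing on these results is available. The compounds shown leave open whether an amine or a carboxylic acid on the phenyl, or a longer chain on the ring nitrogen, would also stay within the scatter.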